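The source may hold more compounds than are shown below. What is called first, only, known or untested is meant among the compounds shown, and "the series" means these compounds.

Measured compounds:
compound 1 `COc1cc(N)c(Cl)cc1NC(=O)C1CCN(CC2CCCC2)CC1` — > 10 mg/kg
compound 2 `COc1cc(N)c(Cl)cc1NC(=O)C1CCN(Cc2cccc(C#N)c2)CC1` — > 4 mg/kg
compound 3 `COc1cc(N)c(Cl)cc1NC(=O)C1CCN(C2CCCC2)CC1` — > 10 mg/kg

In a functional assay on the whole organism for antagonist activity, with Mus musculus as the target (a higher number here means that more compound is needed for the effect, a lower number that less compound is needed), compound 1 gives > 10 mg/kg, which is a limit of the assay and not a number. Compound 2 gives > 4 mg/kg, also a limit. Compound 3 gives > 10 mg/kg, again a limit. Compound 1 therefore stands only at a limit, and so do the two further values: the limit of > 10 mg/kg in this assay, at which 2 of the 3 values shown sit, and (the limit of > 4 mg/kg in this assay, at which 1 of the 3 values shown sits). All three measured steps are left unreadable by these limits: a step that the two limits leave unreadable from compound 1 to compound 2, a step that the two limits leave unreadable from compound 1 to compound 3 and a step that the two limits leave unreadable from compound 2 to compound 3.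

Compound 4 `COc1cc(N)c(Cl)cc1NC(=O)C1CCN(Cc2ccc(C)c(C)c2)CC1` differs from compound 1 as follows: 3,4-dimethylphenyl in place of cyclopentyl on a saturated chain carbon bound to an amine nitrogen in a ring. Among the compounds with values here, the step that bears most directly on it is the one from compound 1 to compound 2, where 3-cyanophenyl took the same place on the saturated chain carbon bound to the amine nitrogen in the ring, but its size could not be read from the two limits. No readable step points to a direction, so no step beyond the scatter is expected in this assay, and the outcome for compound 4 is expected to be a further limit more often than a number. Compound 4 is estimated at 10 mg/kg, with a range from 3 mg/kg to 30 mg/kg. The step from compound 1 is estimated as a number no higher from compound 1 to compound 4 (the limit leaves the size open).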

Compound 4, dose for half-maximal effect: > 8 mg/kg
Compound 4 was reported as a limit; the forecaster's own chance of this, stated with the estimate: 75%; the middle value is on the limit's open side.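

In this assay compound 4 gives > 8 mg/kg, a limit of the assay and not a number. Within the data shown here, no step from compound 1, compound 2 or compound 3 to compound 4 can be read from the limits. The compounds shown leave open what dose any of these four groups on the amine nitrogen in the ring actually needs in this assay.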